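Butyl to tert-butyl on the ester of compound 3

The compounds below may be only part of what the source reports. "The series", "measured", "known", "first", "only" and "open" are said of these compounds alone.

Compound 1 `COC(=O)c1cnc(Oc2ccc3c(c2)B(O)OC3)cn1` gives 7590 nM
Compound 2 `CCNC(=O)c1cnc(Oc2ccc3c(c2)B(O)OC3)cn1` gives 79900 nM
Compound 3 `CCCCOC(=O)c1cnc(Oc2ccc3c(c2)B(O)OC3)cn1` gives > 100000 nM

In an ADME assay on Jurkat cells (Homo sapiens) for cytotoxicity, read by MTT assay, with a stated time of 72 h (a lower number here means a stronger inhibitor, a higher number a weaker inhibitor), compound 3 stands at > 100000 nM which is a limit of the assay and not a number. Compound 4 `CC(C)(C)OC(=O)c1cnc(Oc2ccc3c(c2)B(O)OC3)cn1` has not yet been measured. It carries tert-butyl in place of butyl on an oxygen next to a carbonyl group and the two have the same atoms, joined differently.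

Among the measured compounds shown here, no measured step rearranges the same atoms, so the evidence is indirect. The step with propyl in place of hydrogen gave an at least 13-fold higher number from compound 1 to compound 3 (1.11 log units; beyond the scatter) and is large. The step with ethylamino in place of methoxy gave an 11-fold higher number from compound 1 to compound 2 (1.02 log units; beyond the scatter) and is also large. The last step gave an at least 1.2-fold higher number from compound 2 to compound 3 (0.09 log units; that floor lies within the scatter) and shows no separation beyond the scatter. Since compound 4 keeps the four carbons of butyl, no step beyond the scatter is expected, and the expected change is an at least 1.2-fold lower number from compound 3 to compound 4 (0.09 log units; that floor lies within the scatter) as an estimate only. A second limit would not be a surprise. The estimate for compound 4 is 80000 nM with 25000 nM to 200000 nM as its expected range.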

Compound 4, half-maximal inhibitory concentration: > 100000 nM
Compound 4: no number, only a limit; the forecaster's own chance of this, stated with the estimate: 45%; middle value at least 1.2-fold (0.09 log units) from the limit.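

In this assay compound 4 gives > 100000 nM and this is a limit of the assay, not a number. Tert-butyl in place of methyl gives an at least 13-fold higher number from compound 1 to compound 4 (1.11 log units; beyond the scatter) and tert-butoxy in place of ethylamino gives an at least 1.2-fold higher number from compound 2 to compound 4 (0.09 log units; that floor lies within the scatter) so the large gain over the methyl ester, first seen with the butyl ester of compound 3, also holds for the tert-butyl ester. The change from butyl to tert-butyl on this oxygen itself cannot be read, because both esters sit at the same limit: the limit of > 100000 nM in this assay, at which 2 of the 4 values shown sit.

In this assay the compounds shown leave open how an ethyl or isopropyl ester would compare with the methyl ester of compound 1. They also leave open how a carboxylic acid would read on this carbonyl carbon.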